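Benzoyl replaced by 4-chloropyrimidin-2-yl on the amine

A few compounds are considered here, and "the series" means these few. Any claim that something is new, unique, unknown or untested is made for them only; others in the source may bear on it.

compound 1 `C[C@@H](Cn1ccc(-c2ccc(C#N)c(Cl)c2)n1)NC(=O)c1ccccc1`: "not determined" (no result reported) in a functional assay on CWR22R cells (Homo sapiens) for antiproliferative activity, read by CCK-8 assay, with a stated time of 6 days; on this read-out higher numbers stand for weaker inhibition and lower numbers for stronger inhibition
compound 2 `C[C@@H](Cn1ccc(-c2ccc(C#N)c(Cl)c2)n1)Nc1ccccc1`: > 30000 nM in this assay, a limit
compound 3 `C[C@@H](Cn1ccc(-c2ccc(C#N)c(Cl)c2)n1)Nc1cncnc1`: > 30000 nM in this assay, a limit
compound 4 `C[C@@H](Cn1ccc(-c2ccc(C#N)c(Cl)c2)n1)Nc1nccc(Cl)n1`: to be measured in this assay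

Compound 1 has no number in this assay and cannot be placed against the other values. Among the measured compounds shown here, the only step between measured compounds, a step that the two limits leave unreadable from compound 2 to compound 3, has no readable size; both of its ends rest on (the limit of > 30000 nM in this assay, at which 2 of the 3 values shown sit). Compound 4 differs from compound 1 in one place: 4-chloropyrimidin-2-yl in place of benzoyl on an amine nitrogen. For the measured compounds named here, no measured step bears on this change. Going by the values given here, the only guide is that compounds 2 and 3, which also carry a six-membered aromatic ring on the amine nitrogen, both sit at the limit of > 30000 nM in this assay, at which 2 of the 3 values shown sit. Compound 4 is therefore expected near 30000 nM, estimated between 5000 nM and 100000 nM, and most likely to return only a limit again.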

Compound 4, half-maximal inhibitory concentration: > 30000 nM
Compound 4 was reported as a limit; the forecaster's own chance of this, stated with the estimate: 70%; the middle value sits exactly at the limit.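

Compound 4 ends at a limit, as do compound 2 and compound 3, so no step among these three can be read. The compounds shown leave open whether in this assay any group on the amine nitrogen gives a readable value.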